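Cyano for propyl on the styryl aryl ring

This account rests on a few compounds, and the source may have more. Where it says the series, first, only, none or still open, it means among the compounds named here.

Measured compounds:
- compound 1 `CCCc1ccc(/C=C2\CCCN=C2c2cccnc2)cc1`: 890 nM
- compound 2 `COc1ccc2cc(/C=C3\CCCN=C3c3cccnc3)ccc2c1`: 600 nM
- compound 3 `Cc1cc(/C=C2\CCCN=C2c2cccnc2)cc(C)c1O`: 360 nM

In an assay on membranes from brain for displacement of a labelled ligand from Neuronal acetylcholine receptor; alpha4/beta2 (Rattus norvegicus), with a stated time of 3 h (on this read-out lower numbers stand for stronger inhibition and higher numbers for weaker inhibition), compound 1 gives 890 nM, the highest of the three numbers. Compound 2 gives 600 nM, and the two values sit within the scatter of each other, so no order between compound 1 and compound 2 can be claimed. Compound 3 gives 360 nM, a lower number that lies beyond the scatter relative to compound 1. Among the measured compounds shown here, three compounds varying in the aryl portion only, with no single-point step among them, give little basis for a trend.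

Compound 4 `N#Cc1ccc(/C=C2\CCCN=C2c2cccnc2)cc1` has not yet been measured in this assay. It differs from compound 1 by cyano in place of propyl on an aromatic carbon. For the measured compounds named here, with no measured step for this exchange, the expectation rests on the spread already seen across the aryl variants. The step from compound 1 to compound 4 is expected to be small, toward a lower number, a 1.8-fold lower number from compound 1 to compound 4 (0.25 log units; within the scatter), and possibly not beyond the scatter. Compound 4 is estimated at 500 nM, within a range of 150 nM to 1500 nM.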

Compound 4, inhibition constant: 1230 nM
Compound 4: the middle estimate sits 2.5-fold (0.39 log units) below what was measured, and the stated range covers the measured number.
By their numbers in this assay, from the lowest: compounds 3, 2, 1 and 4 (each within the scatter of the next, the first and the last beyond it).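

In this assay, cyano in place of propyl on an aromatic carbon, para to a large group, gives a 1.4-fold higher number from compound 1 to compound 4 (0.14 log units; within the scatter) and is the only single-point step among the compounds shown. At this position, the two groups therefore cannot be told apart on this read-out, even though cyano brings a triple bond and one hydrogen-bond acceptor and propyl brings neither. No independent measurement bears on this result.

As far as these compounds go, it remains open whether any group at this position would separate from propyl beyond the scatter, and an amine, a carboxylic acid or a longer chain in the same place would test this. From the compounds shown here alone, with a single step in hand, it also remains open whether the same exchange would read alike on a different aryl portion.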